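Methoxy to fluoro in the series: working notes

The source may hold more compounds than are shown below. What is called first, only, known or untested is meant among the compounds shown, and "the series" means these compounds.

Compound 1 `N/C(CC(O)c1ccc2ccccc2c1)=N\N=C\c1cccnc1` and compound 2 `COc1ccc(/C=N/N=C(\N)CC(O)c2ccc3ccccc3c2)cc1` share the same core. Among the compounds with values here, in an ADME assay on L6 cells (Rattus norvegicus) for cytotoxicity, read by resazurin assay, with a stated time of 72 h (a lower number here means a stronger inhibitor, a higher number a weaker inhibitor), compound 1 is recorded as "not determined" (no result reported), so compound 2, at 69000 nM, holds the only number available. Compound 3 `N/C(CC(O)c1ccc2ccccc2c1)=N\N=C\c1ccc(F)cc1` has fluoro in place of methoxy on an aromatic carbon, para to a large group: fluoro in place of methoxy on an aromatic carbon. Within the data shown here, no measured step calibrates this change, so in this assay at most a slight move toward lower numbers, not beyond the scatter, is expected. The expected change is a 1.3-fold lower number from compound 2 to compound 3 (0.10 log units; within the scatter). For compound 3 the estimated value is 55000 nM, with an expected range of 22000 nM to 120000 nM.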

Compound 3, half-maximal inhibitory concentration: > 298000 nM
Compound 3 ended at the assay's limit; the forecaster's own chance of this, stated with the estimate: 15%; middle value at least 5.4-fold (0.73 log units) away from the limit.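

On the aromatic carbon para to a large group, the change is not silent in this assay: fluoro in place of methoxy gives an at least 4.3-fold higher number from compound 2 to compound 3 (0.63 log units; beyond the scatter). The reading for compound 3 is a limit of the assay and not a number, so the step fixes only a lower bound on the change: the limit of > 298000 nM in this assay, at which 1 of the 3 values shown sits.

The compounds shown leave open how an amine, a hydroxyl or a chloro at this place would read, and so whether the step follows from methoxy leaving or fluoro entering. Compound 1 stands at "not determined" (no result reported) and adds no comparison.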